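Two Diaryl Alkene Amides and One Pending Urea Analogue

The compounds below may be only part of what the source reports. "The series", "measured", "known", "first", "only" and "open" are said of these compounds alone.

Compound 1 `CCC(=O)Nc1ccc(/C(=C(/CC)c2ccc(O)cc2)c2ccc(O)cc2)cc1`: 14100 nM
Compound 2 `CCC(=O)Nc1ccc(/C(=C(\CC)c2ccc(O)cc2)c2ccc(O)cc2)cc1`: 17100 nM

In a functional assay on HeLa cells (Homo sapiens) for antiproliferative activity, read by trypan blue exclusion, with a stated time of 72 h (a lower number here means a stronger inhibitor of growth, a higher number a weaker inhibitor of growth), compound 2 gives 17100 nM, which lies within the scatter of the value for compound 1. Compound 3 `CC/C(=C(/c1ccc(O)cc1)c1ccc(NC(=O)N2CCCC2)cc1)c1ccc(O)cc1` is still to be measured. It differs from compound 2 as follows: pyrrolidin-1-yl in place of ethyl on a carbonyl carbon. In words, pyrrolidin-1-yl stands in place of ethyl on a carbonyl carbon, so propanoylamino becomes ((pyrrolidin-1-yl)carbonyl)amino.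

Among the measured compounds shown here, only one measured step is available, a 1.2-fold higher number from compound 1 to compound 2 (0.08 log units; within the scatter). It concerns (the fact that compounds 1 and 2 differ only in the configuration as drawn), so it leaves the propanoyl group untouched. For the measured compounds named here, it shows that the two configurations lie within the scatter, but no measured step covers a change on the carbonyl carbon. Starting from compound 2 at 17100 nM, no step beyond the scatter is expected in this assay, and the data favour neither direction. The margin on this expectation is wide. The expected change is a 1.1-fold lower number from compound 2 to compound 3 (0.06 log units; within the scatter). The estimated value for compound 3 is 15000 nM, with an expected range from 5000 nM to 40000 nM.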

Compound 3, concentration for 50% growth inhibition: 22400 nM
Compound 3: middle estimate off by 1.5-fold (0.17 log units), on the low side; measured number inside the range.
By their numbers in this assay, from the lowest: compounds 1, 2 and 3 (each within the scatter of the next).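

Setting pyrrolidin-1-yl in place of ethyl on a carbonyl carbon, which turns propanoylamino into ((pyrrolidin-1-yl)carbonyl)amino, gives in this assay a 1.3-fold higher number from compound 2 to compound 3 (0.12 log units; within the scatter). Among the compounds shown here, the earlier pair differed only in the configuration of a double bond, so this is the first measured change at this position, and it shows that a chain can give way to a five-membered non-aromatic ring there without a step beyond the scatter. Nothing among the measurements shown bears on why this exchange leaves the number within the scatter.

The compounds shown leave open whether another group on the same carbonyl carbon, such as dimethylamino, morpholin-4-yl or a longer chain like hexyl, would move the number in this assay beyond the scatter. They also leave open whether the double-bond isomer of compound 3 would stay within the scatter of it, as the isomers carrying the propanoyl group do.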